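Swapping the Pyrazole on the Amide Nitrogen for tert-Butyl

The source may hold more compounds than are shown below. What is called first, only, known or untested is meant among the compounds shown, and "the series" means these compounds.

Compound 1 `CCN(Cc1ccc(C)s1)C(=O)COc1ccc(C)cc1`: 178 nM
Compound 2 `Cc1ccc(OCC(=O)N(Cc2cccs2)c2c(C)n[nH]c2C)cc1`: 0.3 nM
Compound 3 `CCN(Cc1ccccn1)C(=O)COc1ccc(C)cc1`: 16000 nM

Of the compounds shown here, three have been measured in an assay on HEK293 cells for agonist activity at transient receptor potential cation channel subfamily M member 8 (Homo sapiens), read by fluorescence and calcium flux, with a stated time of 15 min; on this read-out lower numbers stand for an effect already at smaller amounts and higher numbers for an effect only at larger amounts of compound. Compound 2 gives the lowest number of the three, 0.3 nM; compound 1 stands nearest to it with 178 nM, and compound 3 is furthest away at 16000 nM. Within the data shown here, the one step that can be read directly concerns the group on the saturated chain carbon: a 90-fold higher number from compound 1 to compound 3 (1.95 log units; beyond the scatter).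

Compound 4 `Cc1ccc(OCC(=O)N(Cc2cccs2)C(C)(C)C)cc1` is the next compound to be measured. It differs from compound 2 at the amide-type nitrogen: tert-butyl in place of 3,5-dimethyl-1H-pyrazol-4-yl on an amide-type nitrogen.

Among the measured compounds shown here, no measured step touches this position directly. Compound 1 and compound 2 differ at that nitrogen as well as at the thiophene, so their two values can only be set side by side: compound 1 carries a small alkyl group there and gives a far higher number than compound 2. On that basis compound 4 is expected to lose ground against compound 2, with a step of about a 170-fold higher number from compound 2 to compound 4 (2.22 log units; beyond the scatter) in this assay. The estimate for compound 4 is 50 nM, with a range from 5 nM to 500 nM.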

Compound 4, half-maximal effective concentration: 11000 nM
Beside the measured number, compound 4's estimate is 220-fold (2.34 log units) below it; measured number outside the range, above it.
By their numbers in this assay, from the lowest: compound 2; then compound 1; then compounds 4 and 3 (each within the scatter of the next).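

In this assay, among these compounds, the exchange at the amide-type nitrogen gives a 37000-fold higher number from compound 2 to compound 4 (4.56 log units; beyond the scatter) and is the first step that isolates this position, since the earlier compounds differed there only together with a change at the thiophene. With the rest of the structure held constant, the number depends strongly on which group sits on this nitrogen, and tert-butyl does not stand in for 3,5-dimethyl-1H-pyrazol-4-yl. The change removes the aromatic ring, the hydrogen-bond donor and the hydrogen-bond acceptor all at once, so this one step cannot tell which of them matters, and nothing available bears on the reason for it.

The compounds shown leave open whether any ring on this nitrogen would restore a low number, or whether the ring nitrogens and the two methyl groups of the pyrazole are also needed, which a cyclohexyl ring, a phenyl ring or a pyrazole without those methyl groups would begin to separate. They also leave open how an ethyl group on this nitrogen would behave with the unsubstituted thiophene of compound 2 and compound 4.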